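Methoxyphenyl regioisomers: expected lipophilicity of compound 3

The source may hold more compounds than are shown below. What is called first, only, known or untested is meant among the compounds shown, and "the series" means these compounds.

Measured so far:
compound 1, `Cc1ncccc1-c1nc2cn(-c3ccccc3)nc2c(=O)n1C[C@H]1CCCN(C[C@H]2CCCO2)C1`, 1.7
compound 2, `COc1ccc(-n2cc3nc(-c4ccccc4C)n(CC4CCCN(C(C)C)C4)c(=O)c3n2)cc1`, 2.4

Both numbers come from a physicochemical assay for lipophilicity, using the shake flask method, measured as octanol-water partition, with a stated time of 30 min, at pH 7.4; a higher number here means a more lipophilic compound, a lower number a more polar compound. Compound 2 stands highest of the two values recorded, and the gap down to compound 1 is beyond the usual scatter of this assay.

Compound 3, `COc1cccc(-n2cc3nc(-c4ccccc4C)n(CC4CCCN(C(C)C)C4)c(=O)c3n2)c1`, has not yet been measured. It shares every atom with compound 2 but joins them differently: 3-methoxyphenyl in place of 4-methoxyphenyl on an aromatic nitrogen. Going by the values given here, no step between two measured compounds that differ in only one place is available, so nothing measured here tells how such a change moves the read-out.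

With the same atoms and the same count of donors and acceptors on both sides, no step beyond the scatter is expected; the expected step is a number 0.10 log units higher from compound 2 to compound 3 (within the scatter). Compound 3 is therefore estimated at 2.5, with a range from 2.1 to 2.9.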

Compound 3, distribution coefficient: 2.5
Compound 3: middle estimate and measured number agree at the digits printed, and the stated range covers the measured number.
By their numbers in this assay, from the lowest: compound 1; then compounds 2 and 3 (each within the scatter of the next).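

In this assay, going by these compounds alone, the exchange of 4-methoxyphenyl for 3-methoxyphenyl on an aromatic nitrogen gives a number 0.10 log units higher from compound 2 to compound 3 (within the scatter) and is the first one-place step that can be read. For this pair, which has the same atoms and the same counts of donors and acceptors, moving the methoxy group from one named arrangement to the other keeps the read-out inside the scatter, so compound 2 and compound 3 cannot be placed in an order. No supporting measurement bears on this result.

This single pair of isomers says nothing about other groups on that aromatic nitrogen. As far as these compounds go, whether an amine, a carboxylic acid or a longer chain in place of the methoxy group would give a step beyond the scatter remains open.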